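The source may report more compounds than this note shows. Statements on the series, on what has been measured and on what is new or still open speak of the compounds shown alone.

Compound 1 `COCC(=O)N(Cc1ccc(OC)c(O)c1)c1cc(OC)c(OC)c(OC)c1` gives 460 nM in a functional assay on KYSE-450 cells (Homo sapiens) for inhibition, read by MTT assay, with a stated time of 48 h; on this read-out higher numbers stand for weaker inhibition and lower numbers for stronger inhibition. Among the compounds with values here, it stands second highest of the three numbers measured so far: compound 2 `C/C=C/C(=O)N(Cc1ccc(OC)c(N)c1)c1cc(OC)c(OC)c(OC)c1` gives 310 nM, a difference from compound 1 that lies within the scatter, while compound 3 `C/C=C/C(=O)N(Cc1ccc(OC)c(C)c1)c1cc(OC)c(OC)c(OC)c1` gives 32900 nM, far beyond it. Within the data shown here, the one step between measured neighbours, a 110-fold higher number from compound 2 to compound 3 (2.03 log units; beyond the scatter), concerns the substituent on the aromatic ring of the benzyl group and says nothing about the acyl side of the amide.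

Compound 4 `COc1ccc(CN(C(=O)CCCCCl)c2cc(OC)c(OC)c(OC)c2)cc1O` differs from compound 1 only on that acyl side: 3-chloropropyl in place of methoxy on a saturated chain carbon bound to a carbonyl carbon. Cut one bond further out, the methoxymethyl carbonyl becomes a 4-chlorobutyl carbonyl. Among the measured compounds shown here, no measured pair in this set changes the acyl group, so there is no step on which to rest a direction. The expectation for compound 4 is therefore a step of roughly a 1.3-fold higher number from compound 1 to compound 4 (0.12 log units; within the scatter), not clearly beyond the scatter in either direction. Compound 4 is estimated at 600 nM, within a range of 150 nM to 2500 nM.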

Compound 4, half-maximal inhibitory concentration: 770 nM
The estimate for compound 4 lay 1.3-fold (0.11 log units) below the measured number; the range from low to high includes it.
By their numbers in this assay, from the lowest: compounds 2, 1 and 4 (each within the scatter of the next, the first and the last beyond it); then compound 3.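

The acyl side of the amide now has its first readable step in this assay: a 1.7-fold higher number from compound 1 to compound 4 (0.22 log units; within the scatter), for methoxymethyl to 4-chlorobutyl on the carbonyl. This exchange removes the ether oxygen, adds a chlorine and lengthens the chain, yet it does not separate compound 1 from compound 4 in this assay. This contrasts with the ring substituent exchange, a 110-fold higher number from compound 2 to compound 3 (2.03 log units; beyond the scatter), although no evidence here explains the tolerance seen on the acyl side.

Within the data shown here, the single step cannot show how far this tolerance extends, as a longer chain, a terminal amine or a carboxylic acid on the acyl side could behave differently. Also open, as far as these compounds go, is whether the large step between amino and methyl on the ring would carry over to compounds bearing the methoxymethyl or 4-chlorobutyl carbonyl.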